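The source may report more compounds than this note shows. Statements on the series, on what has been measured and on what is new or still open speak of the compounds shown alone.

The compounds here share one core and differ only in the aryl group attached to an aromatic nitrogen. Compound 2 `COc1ccc(-n2nncc2CN2C(=O)C3(C(C#N)=C(N)Oc4c3c3nc5ccccc5nc3c3ccccc43)c3ccccc32)cc1` carries a 4-methoxyphenyl group at that position. In a functional assay on A549 cells (Homo sapiens) for antiproliferative activity, read by MTT assay, with a stated time of 48 h (a higher number here means a weaker inhibitor, a lower number a stronger inhibitor), compound 2 gives only a limit of the assay, > 50000 nM. Compound 1 `N#CC1=C(N)Oc2c(c3nc4ccccc4nc3c3ccccc23)C12C(=O)N(Cc1cnnn1-c1cccc(Br)c1)c1ccccc12` carries a 3-bromophenyl group instead. In this assay compound 1 likewise reaches only a limit, > 50000 nM. Compound 3 `Cc1cc(C)cc(-n2nncc2CN2C(=O)C3(C(C#N)=C(N)Oc4c3c3nc5ccccc5nc3c3ccccc43)c3ccccc32)c1` carries a 3,5-dimethylphenyl group. In this assay compound 3 also stops at a limit, > 50000 nM. All three values sit at the same limit (the limit of > 50000 nM in this assay, at which 3 of the 3 values shown sit), so the three steps between them cannot be sized: a step that the two limits leave unreadable from compound 1 to compound 2, a step that the two limits leave unreadable from compound 1 to compound 3 and a step that the two limits leave unreadable from compound 2 to compound 3. Compound 4 `N#CC1=C(N)Oc2c(c3nc4ccccc4nc3c3ccccc23)C12C(=O)N(Cc1cnnn1-c1cc(Cl)ccc1Cl)c1ccccc12` is the next member of this series. The change 2,5-dichlorophenyl in place of 4-methoxyphenyl on an aromatic nitrogen again swaps one aryl group for another of matching size, as the earlier swaps did. Those earlier swaps all left the value at the limit, which gives no reason to expect a readable move here. The step expected is a step that the limit leaves unreadable from compound 2 to compound 4, nothing beyond the scatter. Compound 4 is therefore estimated at 70000 nM, with a range from 25000 nM to 250000 nM, most likely reported as a limit once more.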

Compound 4, half-maximal inhibitory concentration: > 50000 nM
Compound 4 was reported as a limit (the forecaster's own chance of this, stated with the estimate: 85%); the middle value is on the limit's open side.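

Compound 4 also stops at a limit, so none of the steps linking it to compound 1, compound 2 and compound 3 in this assay can be read: the limit of > 50000 nM in this assay, at which 4 of the 4 values shown sit.

The compounds shown leave open whether any aryl group on this aromatic nitrogen gives a readable value, and how these four aryl groups truly compare.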